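Amide Aryl Swap on the Shared Core: Compound 4

A few compounds are considered here, and "the series" means these few. Any claim that something is new, unique, unknown or untested is made for them only; others in the source may bear on it.

Among the compounds with values here, compound 3 `O=C(Nc1ccc(Cl)c(-c2nnc3c(Cl)cccn23)c1)c1ccon1` supplies the only number in this set, 42700 nM in a functional assay on A549 cells (Homo sapiens) for antiproliferative activity, read by MTT assay, with a stated time of 72 h; a lower number here means a stronger inhibitor, a higher number a weaker inhibitor. Compound 1 `CS(=O)(=O)c1ccc(C(=O)Nc2ccc(Cl)c(-c3nnc4c(Cl)cccn34)c2)c(Cl)c1` reports only a limit, > 100000 nM. Compound 2 `Cc1cc(Cl)ccc1C(=O)Nc1ccc(Cl)c(-c2nnc3c(Cl)cccn23)c1` likewise stops at a limit, > 100000 nM. Within the data shown here, the one readable step is an at least 2.3-fold lower number from compound 2 to compound 3 (0.36 log units; beyond the scatter), where an aryl gave way to the 1,2-oxazol-3-yl and the number fell. Compound 4 `CS(=O)(=O)c1ccc(C(=O)Nc2ccc(Cl)c(-c3nnc4c(Cl)cccn34)c2)cc1` runs that direction backwards: 4-(methylsulfonyl)phenyl in place of 1,2-oxazol-3-yl on a carbonyl carbon. Compound 1 already carries the same 4-(methylsulfonyl)phenyl amide with one further chlorine. A return to an aryl amide is therefore expected to push the number up, a 2.3-fold higher number from compound 3 to compound 4 (0.37 log units; beyond the scatter), quite possibly to the assay ceiling, because compound 1 sits at the limit of > 100000 nM in this assay, at which 2 of the 3 values shown sit. Compound 4 is estimated at 100000 nM, range 40000 nM to 300000 nM.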

Compound 4, half-maximal inhibitory concentration: > 100000 nM
Compound 4 gave a limit, no number; the forecaster's own chance of this, stated with the estimate: 60%; the middle value lies on the limit itself.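

In this assay compound 4 gives > 100000 nM, which is a limit and not a number. On the carbonyl carbon, the change reads as an at least 2.3-fold higher number from compound 3 to compound 4 (0.36 log units; beyond the scatter), and 1,2-oxazol-3-yl remains the only group shown with a number. The 4-(methylsulfonyl)phenyl amide now sits at the limit both with and without the further chloro, and the steps to compound 4 from compound 1 and compound 2 cannot be read: the limit of > 100000 nM in this assay, at which 3 of the 4 values shown sit.

Open, from the compounds shown here alone, is whether a pyridine ring, a saturated amine such as piperidine, or a carboxylic acid on this carbonyl carbon would give a lower number. Going by these compounds, how far any of the aryl amides lies past the limit also stays unknown.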